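Nitrogen substituent changes across a shared core

The source may report more compounds than this note shows. Statements on the series, on what has been measured and on what is new or still open speak of the compounds shown alone.

Compound 1 `C/C=C/n1cc(/C=C/C(=O)CC(=O)C(=O)OCC)c2ccccc21`. In an assay on isolated protein for inhibition of DNA nucleotidylexotransferase (Homo sapiens), read by scintillation counting, with a stated time of 10 min (a higher number here means a weaker inhibitor, a lower number a stronger inhibitor), compound 1 gives > 40 uM, which is a limit of the assay.
Compound 2 `CCOC(=O)C(=O)CC(=O)/C=C/c1cn(-c2ccc(O)cc2)c2ccccc12`. In this assay compound 2 gives > 40 uM, again a limit of the assay.
Compound 3 `CCOC(=O)C(=O)CC(=O)/C=C/c1cn(Cc2ccccc2)c2ccccc12`. In this assay compound 3 gives > 40 uM, also a limit of the assay.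

All three measured members differ only in the group on the aromatic nitrogen. The steps a step that the two limits leave unreadable from compound 1 to compound 2, a step that the two limits leave unreadable from compound 1 to compound 3 and a step that the two limits leave unreadable from compound 2 to compound 3 cannot be sized because of the limit of > 40 uM in this assay, at which 3 of the 3 values shown sit. Compound 3 therefore stands nowhere in particular among the numbers: its value is a limit, and so are the other two.

Compound 4 `CCOC(=O)C(=O)CC(=O)/C=C/c1cn(Cc2ccc(OC)cc2)c2ccccc12` is the next member. Relative to compound 3 the change is methoxy in place of hydrogen on an aromatic carbon. Within the data shown here, none of the measured steps gives a readable size for any change on the aromatic nitrogen, and none at all for a change on the benzyl ring, so no direction can be read from them. Among the measured compounds shown here, the only guide is that every measured member sits at the limit, and the most plausible expectation is that compound 4 remains there as well, the expected step that the limit leaves unreadable from compound 3 to compound 4 being essentially none beyond the scatter. For compound 4 the estimate in this assay is 50 uM, with a range from 15 uM to 200 uM, and a limit rather than a number is the likelier outcome.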

Compound 4, concentration for 50% inhibition: > 40 uM
Compound 4: a limit, no number; the forecaster's own chance of this, stated with the estimate: 80%; the middle value does not contradict the limit.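

In this assay, the steps from compound 3, compound 2 and compound 1 to compound 4 cannot be read, and compound 4 is itself a limit of the assay: the limit of > 40 uM in this assay, at which 4 of the 4 values shown sit.

The compounds shown leave open whether methoxy on the benzyl ring, or any of the groups on the aromatic nitrogen, changes inhibition at all, and in which direction.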